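The source may hold more compounds than are shown below. What is called first, only, known or untested is meant among the compounds shown, and "the series" means these compounds.

Among the measured compounds shown here, compound 3 `CCCCCCCCCCCC(=O)Nc1ccc(O)cc1` gives 0% in a functional assay on MIA PaCa-2 cells (Homo sapiens) for inhibition, read by MTT assay, with a stated time of 72 h, tested at 10 uM (on this read-out lower numbers stand for less inhibition of growth and higher numbers for more inhibition of growth at the one concentration tested), the lowest of the three numbers measured so far. Compound 1 `CCCCCCCCCCCCNc1ccc(O)cc1` gives 50% in this assay, and compound 2 `CCCCCCCCCCNc1ccc(O)cc1` gives 55%. Compound 4 `CCCCCCCCCC(=O)Nc1ccc(O)cc1` has not yet been measured. It differs from compound 3 by hydrogen in place of ethyl on a saturated chain carbon, nine bonds along the chain from a carbonyl carbon. For the measured compounds named here, the only measured step that bears on this change is the matching shortening of the chain between the two compounds without a carbonyl, a number 5 percentage points higher from compound 1 to compound 2 (within the scatter), which stayed within the scatter. On that basis no step beyond the scatter is expected for compound 4 in this assay. Compound 4 is therefore estimated at 5%, with a range from 0% to 20%. The expected step is a number 5 percentage points higher from compound 3 to compound 4 (within the scatter).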

Compound 4, percent growth inhibition at one concentration: 0%
Estimate against measurement, compound 4: 5 percentage points above; measured number inside the range.
By their numbers in this assay, from the lowest: compounds 3 and 4 (each within the scatter of the next); then compounds 1 and 2 (each within the scatter of the next).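

With hydrogen in place of ethyl, nine bonds along the chain from a carbonyl carbon, the carbonyl core gives no change at the digits printed from compound 3 to compound 4 (within the scatter) in this assay. Compound 4 gives 0%, so neither chain length on this core shows any inhibition of growth at the one concentration tested. The same change now reads alike on two cores: the same change on two cores in this assay, a number 5 percentage points higher (within the scatter) from compound 1 to compound 2 and no change at the digits printed (within the scatter) from compound 3 to compound 4, 5 percentage points apart, within the scatter of two such steps.

Going by these compounds, whether a much shorter chain, such as hexyl, would behave the same on either core stays open. So does whether an amine or a carboxylic acid at the chain end would give the carbonyl core a measurable number.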